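The source may report more compounds than this note shows. Statements on the series, on what has been measured and on what is new or still open speak of the compounds shown alone.

Compound 1, `COC(=O)c1ccc(NCc2cncn2Cc2ccc(-c3ccccc3)cc2)cc1-c1ccccc1`, in a toxicity assay on NIH3T3 cells (Mus musculus) for cytotoxicity, read by resazurin assay; on this read-out lower numbers stand for an effect already at smaller amounts and higher numbers for an effect only at larger amounts of compound: > 1000 nM
Compound 2, `COC(=O)c1ccc(NCc2cncn2Cc2ccccc2F)cc1-c1ccccc1`, in this assay: "not determined" (no result reported)
Compound 3, `CCCC(=O)c1ccc(NCc2cncn2Cc2ccc(-c3ccccc3)cc2)cc1-c1ccccc1`, in this assay: > 10000 nM

In this assay compound 1 reaches only a limit, > 1000 nM, and not a number. Compound 3 likewise stops at a limit, > 10000 nM. For compound 2 no result was reported. Going by the values given here, compound 1 therefore stands at the limit of > 1000 nM in this assay, at which 1 of the 3 values shown sits, and the one step that joins it to another measured compound, a step that the two limits leave unreadable from compound 1 to compound 3, cannot be read in size because both of its ends are limits, the second of them (the limit of > 10000 nM in this assay, at which 1 of the 3 values shown sits).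

The unmeasured compound 4, `COC(=O)c1ccc(NCc2cncn2Cc2ccc(-c3ccccc3)cc2)cc1`, differs from compound 1 in one place: hydrogen in place of phenyl on an aromatic carbon. No measured step touches that position, so nothing shown speaks for a change beyond the scatter. Because compound 1 sits at the limit of > 1000 nM in this assay, at which 1 of the 3 values shown sits, compound 4 is expected to give about 3000 nM in this assay, within 1000 nM to 10000 nM. The estimated step that the limit leaves unreadable from compound 1 to compound 4 is thus expected to stay close to nothing, with a fair chance that compound 4 again returns only a limit.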

Compound 4, half-maximal effective concentration: > 10000 nM
Compound 4: only a limit was reported; the forecaster's own chance of this, stated with the estimate: 70%; middle value at least 3.3-fold (0.52 log units) away from the limit.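

Compound 1 and compound 4 both return only limits in this assay, and the size of the step between them cannot be read. The compounds shown leave open where the effect of compound 1, compound 3 or compound 4 actually sets in, and whether hydrogen in place of phenyl shifts it at all.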